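The source may hold more compounds than are shown below. What is called first, only, known or untested is meant among the compounds shown, and "the series" means these compounds.

Working notes on the series.

Compound 1, `Oc1cccc2cc(-c3ccccc3)ccc12`, is the parent of the set. In an assay for binding affinity to 17-beta-hydroxysteroid dehydrogenase type 1 (Homo sapiens), with a stated time of 20 min, tested at 1 uM (on this read-out higher numbers stand for more inhibition at the one concentration tested (going by the name of the read-out) and lower numbers for less inhibition), compound 1 gives < 10%, which is a limit of the assay and not a number; compound 1 therefore sits at the limit of < 10% in this assay, at which 1 of the 3 values shown sits, and where it truly stands on this read-out is open.

Two measured steps start from compound 1. Compound 2, `OCc1ccc(-c2ccc3c(O)cccc3c2)cc1`, gives 14% in this assay, and the step is a number at least 4 percentage points higher from compound 1 to compound 2 (that floor lies within the scatter). Compound 3, `CNS(=O)(=O)c1ccc(-c2ccc3c(O)cccc3c2)cc1`, gives 12%, with the step of a number at least 2 percentage points higher from compound 1 to compound 3 (that floor lies within the scatter). Between compound 2 and compound 3 the step is a number 2 percentage points lower from compound 2 to compound 3 (within the scatter).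

Compound 4, `CNC(=O)c1cccc(-c2ccc3c(O)cccc3c2)c1`, is not yet measured. It differs from compound 1 by methylcarbamoyl in place of hydrogen on an aromatic carbon. The two measured steps that start from compound 1 both bear on it, and both are floors lying inside the scatter; the step between compound 2 and compound 3 is also inside the scatter. Going by the values given here, no step in the set exceeds the scatter, so a step of no more than the scatter, if any, is expected in this assay for compound 4 as well.

Compound 4 is therefore expected to give 12% in this assay, with a range from 4% to 22%. The step this estimate means is a number at least 2 percentage points higher from compound 1 to compound 4 (that floor lies within the scatter), expected to stay within the scatter.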

Compound 4, a percentage reported as inhibition, at one concentration (the size of the read-out at that concentration, not a potency): < 10%
Compound 4 ended at the assay's limit; the forecaster's own chance of this, stated with the estimate: 35%; at least 2 percentage points between middle value and limit.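

Compound 1 and compound 4 both end at a limit of the assay, not at a number, in this assay, so the step between them cannot be read: the limit of < 10% in this assay, at which 2 of the 4 values shown sit.

The compounds shown leave open where compound 1 and compound 4 truly stand on this read-out, and whether methylcarbamoyl in place of hydrogen on an aromatic carbon changes inhibition at all.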